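The source may hold more compounds than are shown below. What is called first, only, known or untested is meant among the compounds shown, and "the series" means these compounds.

Compound 1 `CCCCC(Sc1nc(Cl)cc(Nc2ccc3ncccc3c2)n1)C(=O)OCC` — in an assay for inhibition of Polyunsaturated fatty acid 5-lipoxygenase (Homo sapiens) (on this read-out higher numbers stand for weaker inhibition and lower numbers for stronger inhibition), compound 1 gives 1100 nM.
Compound 2 `CCOC(=O)CSc1nc(Cl)cc(Nc2cccc3c2CCC3)n1` — compound 2 gives 3200 nM.
Compound 3 `CCOC(=O)CSc1nc(Cl)cc(Nc2ccc3ncccc3c2)n1` — compound 3 gives 2600 nM.

Compound 3 stands second highest of these three numbers: its value lies within the scatter of compound 2, and beyond the scatter above compound 1. Compound 4 `CCOC(=O)C(Sc1nc(Cl)cc(Nc2ccc3ncccc3c2)n1)c1ccccc1` differs from compound 3 by phenyl in place of hydrogen on a saturated chain carbon bound to a carbonyl carbon and a sulfur. Among the compounds with values here, the one measured step that bears on this change is a 2.4-fold higher number from compound 1 to compound 3 (0.37 log units; beyond the scatter). Within the data shown here, putting a phenyl in where the hydrogen was is a change of the same kind run in the opposite direction, so a modest lowering of the number is expected for compound 4, with the reservation that phenyl is a different group from butyl and no other pair informs this. Compound 4 is therefore expected to give 1300 nM, with a range from 500 nM to 3500 nM, an expected step of a 2.0-fold lower number from compound 3 to compound 4 (0.30 log units; within the scatter).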

Compound 4, half-maximal inhibitory concentration: 1200 nM
Compound 4: middle estimate off by 1.1-fold (0.03 log units), on the high side, and the stated range covers the measured number.
By their numbers in this assay, from the lowest: compounds 1 and 4 (each within the scatter of the next); then compounds 3 and 2 (each within the scatter of the next).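

Phenyl in place of hydrogen on a saturated chain carbon bound to a carbonyl carbon and a sulfur gives a 2.2-fold lower number from compound 3 to compound 4 (0.34 log units; beyond the scatter) and thus acts in the same direction as butyl, so this position accepts an aromatic ring as well as a chain. Phenyl in place of butyl gives a 1.1-fold higher number from compound 1 to compound 4 (0.04 log units; within the scatter) and so leaves the two groups indistinguishable on this read-out. Nothing measured here explains either step.

On these data alone, it remains open whether an amine, a carboxylic acid or a chain longer than butyl at this carbon would also lower the number. As far as these compounds go, whether phenyl gives a similar step on the core of compound 2 also remains open.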